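This account rests on a few compounds, and the source may have more. Where it says the series, first, only, none or still open, it means among the compounds named here.

Compound 1 `CCn1c(C(=O)N[C@H](C)C(=O)OC)ccc1C(CC)(CC)c1ccc(OCS(=O)(=O)c2ccccc2)c(C)c1` gives > 50000 nM, a limit of the assay.
Compound 2 `CCn1c(C(=O)NCCC(=O)OC)ccc1C(CC)(CC)c1ccc(OCS(=O)(=O)c2ccccc2)c(C)c1` gives > 50000 nM, likewise a limit.
Compound 3 `CCn1c(C(=O)N[C@H](CO)CCO)ccc1C(CC)(CC)c1ccc(OCS(=O)(=O)c2ccccc2)c(C)c1` gives 15900 nM.

In a functional assay on BXPC-3 cells (Homo sapiens) for antiproliferative activity, read by MTT assay, with a stated time of 24 h (a higher number here means a weaker inhibitor, a lower number a stronger inhibitor), compound 2 therefore sits at the limit, where two of the three values rest (the limit of > 50000 nM in this assay, at which 2 of the 3 values shown sit), and only compound 3 gives a number. Compound 4 `CCn1c(C(=O)N[C@H](C)C(=O)O)ccc1C(CC)(CC)c1ccc(OCS(=O)(=O)c2ccccc2)c(C)c1` differs from compound 2 in one place: 1-carboxyethyl in place of 2-(methoxycarbonyl)ethyl on an amide-type nitrogen. Among the compounds with values here, two measured steps touch this position. The step that the two limits leave unreadable from compound 1 to compound 2 gives no readable size. The step of an at least 3.1-fold lower number from compound 2 to compound 3 (0.49 log units; beyond the scatter) shows that a change at this nitrogen can lower the number at least modestly. A modest lowering is expected, as an at least 1.2-fold lower number from compound 2 to compound 4 (0.09 log units; that floor lies within the scatter), though the result may again be a limit. Compound 4 is estimated at 40000 nM, between 12000 nM and 100000 nM.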

Compound 4, half-maximal inhibitory concentration: 20100 nM
For compound 4 the middle estimate is 2.0-fold (0.30 log units) above the measured one; measured number inside the range.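

In this assay, hydrogen in place of the methyl on the ester oxygen is a single small change that already moves the result off the limit, giving an at least 2.4-fold lower number from compound 1 to compound 4 (0.39 log units; beyond the scatter). The 1-carboxyethyl group in place of 2-(methoxycarbonyl)ethyl gives an at least 2.4-fold lower number from compound 2 to compound 4 (0.39 log units; beyond the scatter). The 1-carboxyethyl and 3-hydroxy-1-(hydroxymethyl)propyl groups cannot be told apart, with a 1.3-fold higher number from compound 3 to compound 4 (0.10 log units; within the scatter).

As far as these compounds go, whether an amine at the end of this chain, or a carboxylic acid on a longer chain, would lower the number further stays open. The two esters also have no readable size, only a limit: the limit of > 50000 nM in this assay, at which 2 of the 4 values shown sit.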